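The compounds below may be only part of what the source reports. "The series", "measured", "known", "first", "only" and "open" are said of these compounds alone.

Compound 1 `CC(/C=C/C1=CCCCC1(C)C)=C\C=C\C(C)=C\COC(=O)c1cc(O)c(O)c(O)c1` and compound 2 `CC(/C=C/C1=CCCCC1(C)C)=C\C=C\C(C)=C\COC(=O)c1cc(O)ccc1O` share one long unsaturated chain joined through an ester to a phenyl ring that carries hydroxyl groups. In an assay on B16-F10 cells for inhibition of Tyrosinase (Mus musculus), tested at 5 uM (on this read-out lower numbers stand for less inhibition and higher numbers for more inhibition at the one concentration tested (going by the name of the read-out)), compound 1 gives 49.6%, and compound 2 gives 31.3%. The change a number 18.3 percentage points lower from compound 1 to compound 2 (beyond the scatter) came with 2,5-dihydroxyphenyl in place of 3,4,5-trihydroxyphenyl on a carbonyl carbon. On these two numbers compound 2 stands lowest, with compound 1 above it beyond the scatter.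

Compound 3 `CC(/C=C/C1=CCCCC1(C)C)=C\C=C\C(C)=C\COC(=O)c1c(O)cccc1O` differs from compound 2 by 2,6-dihydroxyphenyl in place of 2,5-dihydroxyphenyl on a carbonyl carbon. Going by the values given here, no measured step moves one hydroxyl group around the ring while keeping two of them, so the only step known, from compound 1 to compound 2, bears on this change only loosely. The step of a number 1.3 percentage points lower from compound 2 to compound 3 (within the scatter) is therefore expected to stay within the scatter. Compound 3 is estimated to give 30% in this assay, with a range from 10% to 50%.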

Compound 3, a percentage reported as inhibition, at one concentration (the size of the read-out at that concentration, not a potency): 45.4%
For compound 3 the middle estimate is 15.4 percentage points below the measured one, within the range that was stated.
By their numbers in this assay, from the lowest: compound 2; then compounds 3 and 1 (each within the scatter of the next).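

With the same atoms on the ring, 2,6-dihydroxyphenyl in place of 2,5-dihydroxyphenyl on a carbonyl carbon gives a number 14.1 percentage points higher from compound 2 to compound 3 (beyond the scatter) in this assay, so the arrangement of the hydroxyl groups alone can shift this read-out. The earlier step changed the number and the arrangement of the hydroxyl groups together, whereas this one separates out the arrangement. Going the other way, 2,6-dihydroxyphenyl in place of 3,4,5-trihydroxyphenyl gives a number 4.2 percentage points lower from compound 1 to compound 3 (within the scatter), so in this set a ring with fewer hydroxyl groups does not necessarily mean a lower number. Nothing available here explains why the arrangement matters.

Still open, from the compounds shown here alone, is how a ring bearing a single hydroxyl group or methoxy groups would behave at this position. It is also unknown whether an amide could replace the ester linking ring and chain.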